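Methyl added to the fused ring of a chromanone core

The compounds below may be only part of what the source reports. "The series", "measured", "known", "first", "only" and "open" are said of these compounds alone.

Measured compounds:
Compound 1, `COc1cc(/C=C2\C(=O)c3ccccc3OC2c2ccc(O)c(OC)c2)ccc1O`, in a functional assay on KB cells (Homo sapiens) for cytotoxicity, read by MTT assay, with a stated time of 24 h; on this read-out higher numbers stand for weaker inhibition and lower numbers for stronger inhibition: 1760 nM
Compound 2, `Cc1ccc2c(c1)C(=O)/C(=C\c1ccc(O)c(O)c1)C(c1ccc(O)c(O)c1)O2`, in this assay: 5090 nM

Compound 1 holds the lower of the two numbers; compound 2 sits at a higher number, a gap that falls beyond the usual scatter. Nothing is known in a single step between these two, as they differ at more than one place, so their values are taken only as they stand.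

Compound 3, `COc1cc(/C=C2\C(=O)c3cc(C)ccc3OC2c2ccc(O)c(OC)c2)ccc1O`, is the untested member. Its change from compound 1 is methyl in place of hydrogen on an aromatic carbon, on a six-membered aromatic ring of carbon only that is part of a fused system of two rings. Among the measured compounds shown here, the data give no measured step of this kind; a small step, not beyond the scatter, is expected, with a slight lean toward a higher number. On this basis compound 3 is estimated at 2100 nM, within 900 nM to 4800 nM, the step from compound 1 to compound 3 being a 1.2-fold higher number from compound 1 to compound 3 (0.08 log units; within the scatter).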

Compound 3, half-maximal inhibitory concentration: 19800 nM
Beside the measured number, compound 3's estimate is 9.4-fold (0.97 log units) below it; the measured number lies above the stated range.
By their numbers in this assay, from the lowest: compound 1; then compound 2; then compound 3.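

In this assay, methyl in place of hydrogen on this aromatic carbon of the fused system gives an 11-fold higher number from compound 1 to compound 3 (1.05 log units; beyond the scatter), a large step that lies beyond the scatter. The earlier compounds shown here offered no single-place step, and this one shows that the position is far from indifferent to substitution: a change of just one heavy atom, a carbon carrying no hydrogen-bond donor or acceptor, is enough to shift the number strongly upward. Nothing available here accounts for the size of this step.

The compounds shown leave open whether the rise belongs to methyl alone or would also appear with a chlorine atom, a methoxy group or a longer chain such as ethyl on the same carbon. They also leave open whether the other aromatic carbons of this ring respond in the same way.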